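The source may hold more compounds than are shown below. What is called first, only, known or untested is meant among the compounds shown, and "the series" means these compounds.

Values in a functional assay on Raji cells (Homo sapiens) for antiproliferative activity, read by MTT assay, with a stated time of 48 h; a lower number here means a stronger inhibitor, a higher number a weaker inhibitor:
- compound 1 `Cn1c(N)c(-c2nc3ccccc3[nH]2)c2nc(C#N)c(C#N)nc21`: > 50000 nM (a limit of the assay, not a number)
- compound 2 `CCN(CC)CCn1c(N)c(-c2nc3ccccc3[nH]2)c2nc(C#N)c(C#N)nc21`: 8950 nM
- compound 3 `CN(C)CCCn1c(N)c(-c2nc3ccccc3[nH]2)c2nc(C#N)c(C#N)nc21`: 1230 nM

Of the two actual numbers, compound 2 holds the higher one, and the gap is a 7.3-fold lower number from compound 2 to compound 3 (0.86 log units; beyond the scatter). Compound 1 gives only a limit.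

Compound 4 `CCN(CC)CCn1c(N)c(-c2nc3cc(Cl)ccc3[nH]2)c2nc(C#N)c(C#N)nc21` keeps the diethylamino chain of compound 2 and has chloro in place of hydrogen on an aromatic carbon, turning 1H-benzimidazol-2-yl into 5-chloro-1H-benzimidazol-2-yl: chloro in place of hydrogen on an aromatic carbon.

Going by the values given here, no measured step touches this ring. All the steps change the chain on the aromatic nitrogen: an at least 5.5-fold lower number from compound 1 to compound 2 (0.74 log units; beyond the scatter), an at least 40-fold lower number from compound 1 to compound 3 (1.60 log units; beyond the scatter) and a 7.3-fold lower number from compound 2 to compound 3 (0.86 log units; beyond the scatter). They show that this assay responds to chain changes beyond the scatter, but they give no size for a chloro change, so they bear on it only indirectly. The expectation therefore starts from compound 2 at 8950 nM, with a wide margin. A small shift toward a lower number is expected, no larger than the chain steps, and it may not clear the scatter. The expected step is a 2.0-fold lower number from compound 2 to compound 4 (0.30 log units; within the scatter). For compound 4 the estimated value is 4500 nM, with an expected range of 1500 nM to 13000 nM.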

Compound 4, half-maximal inhibitory concentration: 31500 nM
Beside the measured number, compound 4's estimate is 7.0-fold (0.85 log units) below it; measured number outside the range, above it.
By their numbers in this assay, from the lowest: compound 3; then compound 2; then compound 4. At a limit, above all of these: compound 1.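

In this assay, chloro in place of hydrogen on the aromatic carbon that gives 5-chloro-1H-benzimidazol-2-yl weakens the series, with a 3.5-fold higher number from compound 2 to compound 4 (0.55 log units; beyond the scatter), so the response is no longer confined to the chain on the aromatic nitrogen: a change on the six-membered aromatic ring of the fused system also moves the read-out beyond the scatter. Going by these compounds alone, this single step, taken with the diethylamino chain in place, is the only reading at this position; it runs toward weaker inhibition, and nothing in the data accounts for that direction. Compound 4 still gives a real number, so the step can be read, and the one value resting on a limit remains that of compound 1: the limit of > 50000 nM in this assay, at which 1 of the 4 values shown sits.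

Whether chloro carries the same penalty on the dimethylamino chain of compound 3, the strongest chain shown so far, remains open. Also open, as far as these compounds go, is how this position responds to a different group, such as fluoro, methoxy or an amine, and so whether the loss is specific to chloro or follows any replacement of hydrogen there.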